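Changing the Aryl Group on the Ring Nitrogen

The source may report more compounds than this note shows. Statements on the series, on what has been measured and on what is new or still open speak of the compounds shown alone.

Of the compounds shown here, two sharing one core have been tested in a functional assay on PC-12 cells (Rattus norvegicus) for cytotoxicity, read by MTT assay, with stated times of 2 h and 24 h, tested at 5 uM; on this read-out higher numbers stand for a stronger effect at the one concentration tested and lower numbers for a weaker effect. Compound 1 `COc1ccc(-n2nc(-c3ccc(C(F)(F)F)cc3O)nc2-c2ccccc2O)cc1` gives 86.6%. Compound 2 `COc1ccccc1-n1nc(-c2ccc(C(F)(F)F)cc2O)nc1-c1ccccc1O`, which carries a 2-methoxyphenyl in place of the 4-methoxyphenyl on the aromatic nitrogen, gives 85.6%. The only measured step, a number 1 percentage points lower from compound 1 to compound 2 (within the scatter), lies within the scatter, so on the numbers shown compound 2 stands beside compound 1 with no separation that can be trusted.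

Compound 3 `Oc1cc(C(F)(F)F)ccc1-c1nc(-c2ccccc2O)n(-c2cccc(F)c2)n1` has not yet been measured. Its change from compound 2 is 3-fluorophenyl in place of 2-methoxyphenyl on an aromatic nitrogen. Among the measured compounds shown here, no measured step shows this exact exchange. For the measured compounds named here, the one step that bears on it, a number 1 percentage points lower from compound 1 to compound 2 (within the scatter), shows that exchanging 4-methoxyphenyl for 2-methoxyphenyl at that nitrogen left the read-out unchanged beyond the scatter. On that basis the expected step is a number 1.6 percentage points lower from compound 2 to compound 3 (within the scatter), meaning no movement beyond the scatter in either direction. Compound 3 is therefore estimated at 84% in this assay, within a range from 70% to 94%.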

Compound 3, a percentage reported as activity, at one concentration (the size of the read-out at that concentration, not a potency): 87.7%
Estimate against measurement, compound 3: 3.7 percentage points below, and the stated range covers the measured number.
By their numbers in this assay, from the lowest: compounds 2, 1 and 3 (each within the scatter of the next).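

Up to this point the aryl group on the ring nitrogen had differed only in where its methoxy sat, whereas compound 3 replaces the whole substituent, with the 3-fluorophenyl carrying fluorine and no hydrogen-bond acceptor in place of the oxygen of the 2-methoxyphenyl. In this assay the exchange gives a number 2.1 percentage points higher from compound 2 to compound 3 (within the scatter) and, against the other methoxy compound, a number 1.1 percentage points higher from compound 1 to compound 3 (within the scatter) and so neither step separates the compounds. For these three compounds, then, the read-out at this nitrogen does not distinguish a methoxy group in either of its two places from a fluorine on the ring, and nothing available explains why.

Going by these compounds, all three compounds keep a substituted phenyl ring on this nitrogen, so it remains open whether the read-out would hold with a small methyl group, a longer alkyl chain, or a phenyl ring carrying an amine or a carboxylic acid. Because each compound is shown at only one concentration, these numbers also leave open whether the three would still sit together at other concentrations.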